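Amide-aryl substitution in an azo-indole series

This account rests on a few compounds, and the source may have more. Where it says the series, first, only, none or still open, it means among the compounds named here.

Measured compounds:
- compound 1 `O=C(Nc1ccccc1)c1ccc(/N=N\c2c[nH]c3ccccc23)cc1`: 103000 nM
- compound 2 `Cc1cccc(NC(=O)c2ccc(/N=N\c3c[nH]c4ccccc34)cc2)c1C`: 272000 nM
- compound 3 `Cc1ccc(C)c(NC(=O)c2ccc(/N=N\c3c[nH]c4ccccc34)cc2)c1`: 544000 nM

All numbers come from a functional assay on HCT-116 cells (Homo sapiens) for inhibition, read by MTT assay, with a stated time of 72 h; on this read-out lower numbers stand for stronger inhibition and higher numbers for weaker inhibition. On these numbers compound 1 gives the lowest value of the set; the step of a 2.6-fold higher number from compound 1 to compound 2 (0.42 log units; beyond the scatter) and the step of a 5.3-fold higher number from compound 1 to compound 3 (0.72 log units; beyond the scatter) both go to higher numbers, while the step of a 2.0-fold higher number from compound 2 to compound 3 (0.30 log units; within the scatter) stays within the scatter.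

Compound 4 `O=C(Nc1cccc(Cl)c1)c1ccc(/N=N\c2c[nH]c3ccccc23)cc1` is not yet measured. Relative to compound 1 the change is chloro in place of hydrogen on an aromatic carbon. Among the compounds with values here, no measured step adds a chloro group; the only steps available put methyl groups onto the same ring on the amide-type nitrogen, and each of those raised the number by a modest margin. Chloro is a different group, so the methyl steps bear on it only loosely. The working expectation is a small step upward, or none beyond the scatter.

The estimate for compound 4 is 150000 nM, with a range of 60000 nM to 400000 nM, corresponding to an expected step of a 1.5-fold higher number from compound 1 to compound 4 (0.16 log units; within the scatter).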

Compound 4, half-maximal inhibitory concentration: 80000 nM
For compound 4 the middle estimate is 1.9-fold (0.27 log units) above the measured one; the measured number falls inside the stated range.
By their numbers in this assay, from the lowest: compounds 4 and 1 (each within the scatter of the next); then compounds 2 and 3 (each within the scatter of the next).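

Working from this assay, chloro in place of hydrogen on the ring on the amide-type nitrogen gives a 1.3-fold lower number from compound 1 to compound 4 (0.11 log units; within the scatter), so unlike the two dimethylphenyl groups, this substitution makes no step beyond the scatter from the unsubstituted phenyl. The ring therefore does not respond to every added group with a higher number, and the 3-chlorophenyl group sits clearly lower than either dimethylphenyl group, with a 3.4-fold lower number from compound 2 to compound 4 (0.53 log units; beyond the scatter) and a 6.8-fold lower number from compound 3 to compound 4 (0.83 log units; beyond the scatter) both beyond the scatter. Nothing at hand accounts for this difference between chloro and the paired methyl groups.

Open, from the compounds shown here alone, is whether chloro elsewhere on this ring would behave the same way, or whether a single methyl group would already raise the number. Also open, going by these compounds, is what an amine or a carboxylic acid on this ring would do.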